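The compounds below may be only part of what the source reports. "The series", "measured", "known", "first", "only" and "open" are said of these compounds alone.

Working notes on the series in a functional assay on J774 cells (Mus musculus) for cytotoxicity, read by resazurin assay, with a stated time of 72 h; a higher number here means a weaker inhibitor, a lower number a stronger inhibitor.

Among the compounds with values here, compound 1 `O=S(=O)(Nc1cccc(CO)c1)c1ccc(-c2ccc3cc[nH]c3c2)cc1` is the one member with a number here: in this assay compound 1 gives 2500 nM. Compound 2 `O=C(Nc1cccc(CO)c1)c1ccc(-c2ccccc2)cc1` is reported only as a limit of this assay, > 15000 nM. Compound 3 `O=C(Nc1cccc(CO)c1)c1ccc(-c2ccc(F)cc2F)cc1` likewise stands at a limit of this assay, > 15000 nM. The step that the two limits leave unreadable from compound 2 to compound 3 therefore cannot be sized, since both of its ends rest on (the limit of > 15000 nM in this assay, at which 2 of the 3 values shown sit). Within the data shown here, compound 1 thus stands alone as the single measured value, with the two others at the limit.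

Compound 4 `O=S(=O)(Nc1cccc(CO)c1)c1ccc(-c2ccc(F)cc2F)cc1` is not yet measured. It differs from compound 1 by 2,4-difluorophenyl in place of 1H-indol-6-yl on an aromatic carbon. Among the measured compounds shown here, no measured pair carries this same change: the pair from compound 2 to compound 3 exchanges phenyl for 2,4-difluorophenyl on a different core and gives no readable size, while compound 1 and compound 4 share the same core. For the measured compounds named here, the only guidance is that the 2,4-difluorophenyl member compound 3 stands at the limit, and the sole number in the set belongs to the indolyl member compound 1.

The expectation for compound 4 is therefore loose: an estimated step of a 3.2-fold higher number from compound 1 to compound 4 (0.51 log units; beyond the scatter) toward weaker inhibition, with a real chance that only a limit is returned. Compound 4 is expected at 8000 nM, within 2500 nM to 20000 nM.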

Compound 4, half-maximal inhibitory concentration: 300 nM
For compound 4 the middle estimate is 27-fold (1.43 log units) above the measured one; the measured number lies below the stated range.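

In this assay, within the data shown here, the position para to a large group on the shared core responds to the exchange of 1H-indol-6-yl for 2,4-difluorophenyl, with an 8.3-fold lower number from compound 1 to compound 4 (0.92 log units; beyond the scatter), and this is the only change so far with a readable size. Compound 3, which carries the same 2,4-difluorophenyl on an amide in place of the sulfonamide, is reported only as a limit of the assay, > 15000 nM. The 2,4-difluorophenyl group therefore does not go with a limit value on every core, since compound 4 returns a measured number, while the step between the two amide members still cannot be read: the limit of > 15000 nM in this assay, at which 2 of the 4 values shown sit.

One pair cannot separate the loss of the five-membered ring, the loss of the hydrogen-bond donor and the entry of the two fluorine atoms as the source of the lower number. Also open, going by these compounds, is how an unsubstituted phenyl, an aminomethyl group or a carboxylic acid at this position would read on the sulfonamide core in this assay.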